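A few compounds are considered here, and "the series" means these few. Any claim that something is new, unique, unknown or untested is made for them only; others in the source may bear on it.

The compounds share one core, drawn out in compound 3 `CC[C@H](C)/N=c1\c(O)c(O)\c1=N/Cc1ccc(C#N)cc1`. Among the compounds with values here, in a functional assay for inhibition, with Rattus norvegicus as the target (on this read-out higher numbers stand for weaker inhibition and lower numbers for stronger inhibition), compound 3 gives 2200 nM, the highest of the three numbers measured so far. Compound 1 `CCc1cc(C#N)ccc1C/N=c1\c(O)c(O)\c1=N/[C@H](C)C(C)(C)C` sits close by: in this assay compound 1 gives 2000 nM, and the two values lie within the scatter of each other. Compound 2 `CCC(C)(C)Nc1c(NCc2c(C)cc(Cl)cc2Cl)c(=O)c1=O` stands apart: in this assay compound 2 gives 100 nM, a far lower number than that of compound 3 and well beyond the scatter. Compound 2 differs from compound 3 in more than one place, so its value alone cannot be tied to any single change.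

The next compound, compound 4 `CCC(C)(C)/N=c1\c(O)c(O)\c1=N/Cc1ccc(C#N)cc1`, differs from compound 3 in one place: 1,1-dimethylpropyl in place of sec-butyl on a double-bonded nitrogen. Within the data shown here, no measured pair in the set shows this exact change on its own. Compound 2, which also carries the 1,1-dimethylpropyl group, gives the lowest number of the three, but it differs elsewhere as well, so only part of that gap can be credited to the chain. The step from compound 3 to compound 4 is therefore expected to be a 2.4-fold lower number from compound 3 to compound 4 (0.39 log units; beyond the scatter), toward stronger inhibition, probably beyond the scatter but with wide uncertainty. Compound 4 is expected to give about 900 nM, within a range from 250 nM to 3000 nM.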

Compound 4, half-maximal inhibitory concentration: 1100 nM
Compound 4: the middle estimate sits 1.2-fold (0.09 log units) below what was measured, within the range that was stated.
By their numbers in this assay, from the lowest: compound 2; then compounds 4, 1 and 3 (each within the scatter of the next).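

In this assay, the change to 1,1-dimethylpropyl in place of sec-butyl on a double-bonded nitrogen can now be read on its own, and it amounts to a 2.0-fold lower number from compound 3 to compound 4 (0.30 log units; within the scatter). This position therefore tolerates one further carbon and the loss of the defined stereocentre, with the branched five-carbon chain and the branched four-carbon chain giving values that cannot be told apart in this read-out. Nothing available explains why the step is this small, and no separate measurement bears on the result.

The compounds shown leave open whether a group of another kind on this nitrogen, such as a cyclohexyl ring, a longer straight chain or a chain ending in an amine, would shift the number beyond the scatter. They also leave open how the other stereoisomer of the sec-butyl group would compare with compound 3, and whether the same exchange of chains would give a similar step on a compound with a different group on the second nitrogen.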